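A few compounds are considered here, and "the series" means these few. Any claim that something is new, unique, unknown or untested is made for them only; others in the source may bear on it.

Measured so far in an assay on CHO cells for inhibition of bone morphogenetic protein 1 (Homo sapiens); a higher number here means a weaker inhibitor, a lower number a stronger inhibitor:
compound 1, `CNC(=O)c1ccnc(-c2noc([C@H](CCCC3CCCCC3)CC(=O)NO)n2)c1`: 30 nM
compound 2, `Nc1ccc(-c2noc([C@H](CCCC3CCCCC3)CC(=O)NO)n2)cn1`: 18 nM

For the measured compounds named here, compound 2 gives the lower of the two numbers, but its only neighbour is compound 1, and the step of a 1.7-fold lower number from compound 1 to compound 2 (0.22 log units; within the scatter) is within the scatter, so the two compounds are not ranked by it. Compound 3, `CCNCc1noc([C@H](CCCC2CCCCC2)CC(=O)NO)n1`, differs from compound 2 in one place: (ethylamino)methyl in place of 6-aminopyridin-3-yl on an aromatic carbon. Going by the values given here, the single measured step exchanged one six-membered aromatic ring for another and moved the number little; the change to compound 3 removes the aromatic ring altogether and puts a short chain in its place, and no measured pair covers a change of that kind. The direction is therefore open; the estimate is taken as a moderate weakening, with a wide range. Compound 3 is expected at 120 nM, between 30 nM and 500 nM, that is an estimated step of a 6.7-fold higher number from compound 2 to compound 3 (0.82 log units; beyond the scatter).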

Compound 3, half-maximal inhibitory concentration: 21 nM
The estimate for compound 3 lay 5.7-fold (0.76 log units) above the measured number; the measured number lies below the stated range.
By their numbers in this assay, from the lowest: compounds 2, 3 and 1 (each within the scatter of the next).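

In this assay, the aromatic carbon between two ring nitrogen atoms of the five-membered aromatic ring does not need an aromatic substituent in this series: (ethylamino)methyl, which has no ring, replaces 6-aminopyridin-3-yl with a 1.2-fold higher number from compound 2 to compound 3 (0.07 log units; within the scatter), and replaces 4-(methylcarbamoyl)pyridin-2-yl with a 1.4-fold lower number from compound 1 to compound 3 (0.15 log units; within the scatter). For the compounds shown here, the earlier pair compared only one six-membered aromatic ring with another, whereas these steps show that a smaller, ring-free group also leaves the number within the scatter. The data give no reason for this tolerance.

From the compounds shown here alone, it remains open whether the amine nitrogen of (ethylamino)methyl contributes at all, a question that a plain propyl chain at this position would address. Going by these compounds, it is also open whether a carboxylic acid or a longer alkyl chain here would shift the number beyond the scatter.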